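Methyl addition at two places in one quinoline-acid series

This account rests on a few compounds, and the source may have more. Where it says the series, first, only, none or still open, it means among the compounds named here.

Compound 1 `CCC(c1ccccc1)c1nc2c(C(F)(F)F)cccc2c(C(=O)O)c1O` and compound 2 `CC(C)C(c1ccccc1)c1nc2c(C(F)(F)F)cccc2c(C(=O)O)c1O` share one core; compound 3 `Cc1cc(C(F)(F)F)c2nc(C3(c4ccccc4)CC3)c(O)c(C(=O)O)c2c1` is built on a different core, and the difference between the two cores is not broken down here. In an assay on isolated protein for inhibition of P-selectin glycoprotein ligand 1 (Homo sapiens), read by surface plasmon resonance, tested at 250 uM (a lower number here means less inhibition, a higher number more inhibition at the concentration tested (going by the name of the read-out)), compound 1 gives 55% and compound 2 gives 58%. Compound 3 gives 40% in this assay, the lowest of the three numbers, with gaps to compound 1 and compound 2 that both lie beyond the usual scatter.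

The change from compound 1 to compound 2 is methyl in place of hydrogen on a saturated chain carbon bound to two saturated chain carbons. It produced a number 3 percentage points higher from compound 1 to compound 2 (within the scatter), a step that stays within the scatter.

Compound 4 `CCc1cc(C(F)(F)F)c2nc(C3(c4ccccc4)CC3)c(O)c(C(=O)O)c2c1` has not yet been measured in this assay. It differs from compound 3 by methyl in place of hydrogen on a saturated chain carbon bound to an aromatic carbon. Going by the values given here, this is the same kind of change as the one made on compound 1, though the place is not identical: on compound 1 the carbon is bound to two saturated chain carbons, on compound 3 it is bound to an aromatic carbon. Among the compounds with values here, only this single precedent is available.

Because the earlier change produced a number 3 percentage points higher from compound 1 to compound 2 (within the scatter), the expected step is a number 3 percentage points higher from compound 3 to compound 4 (within the scatter), similar in size to that precedent. Compound 4 is therefore estimated at 43% in this assay, with a likely range from 30% to 56%.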

Compound 4, a percentage reported as inhibition, at one concentration (the size of the read-out at that concentration, not a potency): 40%
Compound 4: middle estimate off by 3 percentage points, on the high side; low and high end bracket the measured number.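

In this assay, methyl in place of hydrogen on a saturated chain carbon bound to an aromatic carbon gives no change at the digits printed from compound 3 to compound 4 (within the scatter). Set beside the earlier step, the same kind of change reads alike on the two cores: the same change on two cores in this assay, a number 3 percentage points higher (within the scatter) from compound 1 to compound 2 and no change at the digits printed (within the scatter) from compound 3 to compound 4, 3 percentage points apart, within the scatter of two such steps This shows that a single methyl addition stays within the scatter on both cores, but it rests on only two pairs, at two non-identical places, and does not show that the change would behave the same way on other cores or at other places.

Still open, on these data alone, is whether a longer chain than ethyl, or an amine or a hydroxyl group at the same carbon, would move the number beyond the scatter on either core. Also open, as far as these compounds go, is whether potency would follow the same pattern, as each reading here comes from one concentration.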